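Halogen swap on the aryl piperazine of the oxazole series

A few compounds are considered here, and "the series" means these few. Any claim that something is new, unique, unknown or untested is made for them only; others in the source may bear on it.

Measured so far:
Compound 1 `CCCc1nc(-c2ccccc2)c(CNCCN2CCN(c3cccc(C(F)(F)F)c3)CC2)o1`: 56.3%
Compound 2 `CCCc1nc(-c2ccccc2)c(CNCCCN2CCN(c3cccc(F)c3)CC2)o1`: 68.9%
Compound 3 `CCCc1nc(-c2ccccc2)c(CNCCN2CCN(c3ccc(C)cc3)CC2)o1`: 48.1%

In an assay on HEK293 cells for inhibition of Voltage-dependent T-type calcium channel subunit alpha-1G (Homo sapiens), read by fluorescence, tested at 10 uM (on this read-out higher numbers stand for more inhibition at the one concentration tested (going by the name of the read-out) and lower numbers for less inhibition), compound 2 gives the highest of the three values; compound 1 and compound 3 both sit lower, and both gaps lie beyond the scatter. The step to be taken from compound 2 leads to compound 4 `CCCc1nc(-c2ccccc2)c(CNCCCN2CCN(c3cccc(Cl)c3)CC2)o1`: chloro in place of fluoro on an aromatic carbon. Among the measured compounds shown here, one measured step bears on an aryl substituent change on this ring nitrogen: a number 8.2 percentage points lower from compound 1 to compound 3 (within the scatter), which did not leave the scatter. A single halogen exchange on an aromatic carbon is therefore expected to give no step beyond the scatter in this assay, in either direction. Compound 4 is estimated at 68% (range 52% to 82%), meaning an expected step of a number 0.9 percentage points lower from compound 2 to compound 4 (within the scatter).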

Compound 4, a percentage reported as inhibition, at one concentration (the size of the read-out at that concentration, not a potency): 65.9%
Estimate against measurement, compound 4: 2.1 percentage points above; the range from low to high includes it.
By their numbers in this assay, from the lowest: compounds 3, 1, 4 and 2 (each within the scatter of the next, the first and the last beyond it).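

In this assay, the exchange of 3-fluorophenyl for 3-chlorophenyl gives a number 3 percentage points lower from compound 2 to compound 4 (within the scatter), the only step shown that swaps one halogen for another. At this place, meta to a large group, the read-out therefore does not separate fluoro from chloro, whereas the earlier step concerned different substituents at different places on the ring. Nothing measured here bears on the reason for this result.

Going by these compounds, it remains open whether bromo or a nitrile at this place would stay within the scatter of compound 2, and how 3-chlorophenyl would read on a shorter chain.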